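This account rests on a few compounds, and the source may have more. Where it says the series, first, only, none or still open, it means among the compounds named here.

In an assay on isolated protein for displacement of a labelled ligand from metabotropic glutamate receptor 5 (Homo sapiens), with a stated time of 60 min, tested at 1 uM (a higher number here means more inhibition at the concentration tested (going by the name of the read-out), a lower number less inhibition), compound 1 `CC1CCN(c2c(S(=O)(=O)c3ccccc3)cnc3ccccc23)CC1` gives 89.2%, while compound 2 `CCN1CCN(c2c(S(=O)(=O)c3ccccc3)cnc3ccccc23)CC1` gives 1.7% and compound 3 `CC1CCN(c2c(S(=O)(=O)c3ccc(F)c(F)c3)cnc3cc(Cl)ccc23)CC1` gives 90%. Compound 2 therefore stands lowest of the three numbers, with compound 1 nearest and compound 3 furthest from it, both far above it. Among the compounds with values here, the only measured step that touches compound 2 is a number 87.5 percentage points lower from compound 1 to compound 2 (beyond the scatter), which is very large, and it shows that exchanging 4-methylpiperidin-1-yl for 4-ethylpiperazin-1-yl on the aromatic carbon removes nearly all of the inhibition.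

Compound 4 `O=S(=O)(c1ccccc1)c1cnc2ccccc2c1N1CCCCCC1` is not yet measured. It differs from compound 2 as follows: azepan-1-yl in place of 4-ethylpiperazin-1-yl on an aromatic carbon. The ring entering is a seven-membered ring with a single hetero atom, so compound 4 moves away from the 4-ethylpiperazin-1-yl of compound 2 and toward the kind of substituent carried by compound 1 and compound 3. Because the step of a number 87.5 percentage points lower from compound 1 to compound 2 (beyond the scatter) was so large in the downward direction when 4-ethylpiperazin-1-yl was introduced, a large rise in this assay is expected when it leaves again, estimated as a number 73.3 percentage points higher from compound 2 to compound 4 (beyond the scatter). The estimate for compound 4 in this assay is accordingly 75%, expected within a range from 40% to 95%.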

Compound 4, a percentage reported as inhibition, at one concentration (the size of the read-out at that concentration, not a potency): 79.9%
Estimate against measurement, compound 4: 4.9 percentage points below; the measured number falls inside the stated range.
By their numbers in this assay, from the lowest: compound 2; then compounds 4, 1 and 3 (each within the scatter of the next, the first and the last beyond it).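

In this assay, exchanging 4-ethylpiperazin-1-yl for azepan-1-yl gives a number 78.2 percentage points higher from compound 2 to compound 4 (beyond the scatter), so the loss seen with compound 2 is not a loss for this position as such: on the carbon ortho to the phenylsulfonyl group, a different ring restores a high number. The comparison with 4-methylpiperidin-1-yl gives a number 9.3 percentage points lower from compound 1 to compound 4 (within the scatter), which is within the scatter, so a seven-membered ring with one hetero atom and the 4-methylpiperidin-1-yl group cannot be told apart here, and the high number is not tied to one ring size or to the methyl branch. Among these three groups on the same core, only the one with two hetero atoms in its ring gives a low number, but nothing available explains this difference.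

The compounds shown leave open whether the low number of compound 2 goes with the second ring nitrogen or with the ethyl group on it, a question that piperazin-1-yl carrying an acetyl group in place of the ethyl, or morpholin-4-yl with a ring oxygen, would address. They also leave open whether a ring is needed at all at this position, as an open-chain diethylamino group would show.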